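A few compounds are considered here, and "the series" means these few. Any claim that something is new, unique, unknown or untested is made for them only; others in the source may bear on it.

For the measured compounds named here, the three compounds measured so far share a core carrying an amide-linked amino acid side. Compound 1 `O=C(CN(c1nc(Cl)nc2[nH]cnc12)C1CC1)N[C@@H](CC(=O)OCc1ccccc1)C(=O)OCc1ccccc1` gives 6.68% in a functional assay on the whole organism (Tail, strain ICR) with Mus musculus as the target, in the tail flick test, with a stated time of 150 min, at a dose of 25 umol/kg by the oral route; a higher number here means a stronger effect of the compound at the dose given, a lower number a weaker effect. Compound 2 `CC(C)(C)OC(=O)NCCCC[C@H](NC(=O)CN(c1ncnc2c1ncn2C1CCCCO1)C1CC1)C(=O)OCc1ccccc1` gives 17.2% in this assay, and compound 3 `CC(C)[C@H](NC(=O)CN(c1nc(Cl)nc2[nH]cnc12)C1CC1)C(=O)O` gives 7.86% in this assay. Among these numbers compound 1 stands lowest; its nearest neighbour is compound 3, whose value lies a little higher but within the scatter, so no order between the two can be claimed, while compound 2 lies beyond the scatter above it.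

Compound 4 `CC(C)C[C@H](NC(=O)CN(c1nc(Cl)nc2[nH]cnc12)C1CC1)C(=O)OCc1ccccc1` has not yet been measured in this assay. It differs from compound 1 in one place: isopropyl in place of benzyloxycarbonyl on a saturated chain carbon, two bonds along the chain from an amide-type nitrogen and a carbonyl carbon. Going by the values given here, no step between measured compounds of this kind is known, so the expectation rests on the position of compound 1 and compound 3 alone, which sit close together at the low end of the range. The step from compound 1 to compound 4 is expected to be small, a number 2.3 percentage points higher from compound 1 to compound 4 (within the scatter), in the upward direction if at all, and likely to stay within the scatter. For compound 4 the estimated value in this assay is 9%, with a range from 2% to 20%.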

Compound 4, a percentage reported as activity, at one dose (the size of the read-out at that dose, not a potency): 5.26%
The estimate for compound 4 lay 3.7 percentage points above the measured number, within the range that was stated.
By their numbers in this assay, from the lowest: compounds 4, 1, 3 and 2 (each within the scatter of the next, the first and the last beyond it).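

At the saturated chain carbon, two bonds along the chain from an amide-type nitrogen and a carbonyl carbon, the exchange of benzyloxycarbonyl for isopropyl in this assay amounts to a number 1.4 percentage points lower from compound 1 to compound 4 (within the scatter). For the compounds shown here, this is the first direct comparison of two compounds that differ in one place, and it shows that the read-out does not separate them, even though the group that leaves has 10 heavy atoms, a six-membered aromatic ring of carbon only and 2 hydrogen-bond acceptors, while the group that enters has 3 heavy atoms, no ring and no acceptors. Nothing measured on these compounds gives a reason for this outcome.

Still open, as far as these compounds go, is whether a carboxylic acid, an amine or a longer chain on this same carbon would also stay within the scatter of compound 1, since both groups compared here carry no charge and no hydrogen-bond donor. From the compounds shown here alone, it is also open whether the same exchange would read alike at another dose or time, or on a compound that gives a larger number in this assay.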